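From methoxy to hexyloxy on compound 3

The source may report more compounds than this note shows. Statements on the series, on what has been measured and on what is new or still open speak of the compounds shown alone.

Compound 1 `Cc1noc(CC2OC(=O)c3ccccc32)n1`: > 40000 nM, a limit
Compound 2 `O=C1OC(Cc2nc(Cc3ccccc3)no2)c2ccccc21`: > 40000 nM, a limit
Compound 3 `COc1ccc(C(O)C2OC(=O)c3c(OC)cc(OC)cc32)cc1`: > 40000 nM, a limit

Compound 3 was tested in an ADME assay on RAW264.7 cells (Mus musculus) for cytotoxicity, read by MTT assay, with a stated time of 24 h, in the absence of a further agent (on this read-out lower numbers stand for stronger inhibition and higher numbers for weaker inhibition), and gives > 40000 nM, which is a limit. The picture is uniform, with the limit of > 40000 nM in this assay, at which 3 of the 3 values shown sit. Compound 3 therefore has no number of its own to start from.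

Compound 4 `CCCCCCOc1ccc(C(O)C2OC(=O)c3c(OC)cc(OC)cc32)cc1` differs from it in one place: pentyl in place of hydrogen on a saturated chain carbon bound to an oxygen on an aromatic ring. In words, this is pentyl in place of hydrogen on a saturated chain carbon bound to an oxygen on an aromatic ring, or methoxy to hexyloxy when cut one bond further out.

Within the data shown here, the only measured step that comes near this change is a step that the two limits leave unreadable from compound 1 to compound 2, which puts phenyl in place of hydrogen on a saturated chain carbon bound to an aromatic carbon. It is a different change on a different core, and its size cannot be read, so it offers no size to carry over.

In this assay, compound 4 is expected to stay close to the limit, with any readable change expected to run towards stronger inhibition. The expected step is an at least 1.1-fold lower number from compound 3 to compound 4 (0.05 log units; that floor lies within the scatter). For compound 4 the estimate is 35000 nM, with an expected range from 15000 nM to 60000 nM.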

Compound 4, half-maximal inhibitory concentration: > 40000 nM
Compound 4 ended at the assay's limit; the forecaster's own chance of this, stated with the estimate: 60%; middle value at least 1.1-fold (0.05 log units) from the limit.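

In this assay compound 4 gives > 40000 nM, which is a limit. Compound 3 also stands at a limit, so no step can be read between compound 3 and compound 4. The picture remains uniform: the limit of > 40000 nM in this assay, at which 4 of the 4 values shown sit.

The compounds shown leave open whether methoxy to hexyloxy changes the result in this assay at all, and what half-maximal inhibitory concentration any of the four compounds has.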